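A few compounds are considered here, and "the series" means these few. Any claim that something is new, unique, unknown or untested is made for them only; others in the source may bear on it.

Compound 1 `COc1ccc(C#CC(C)(C)N)cc1-c1[nH]nc2nc(Nc3ccc(F)cc3F)ccc12`: 52 nM
Compound 2 `COc1ccc(CCC(C)(C)N)cc1-c1[nH]nc2nc(Nc3ccc(F)cc3F)ccc12`: 11 nM
Compound 3 `COc1ccc(C(=O)NC2CCOCC2)cc1-c1[nH]nc2nc(Nc3ccc(F)cc3F)ccc12`: 6 nM

In an in vivo ADME assay on the whole organism for pharmacokinetics, with Rattus norvegicus as the target, at a dose of 1 mg/kg by the oral route (a lower number here means less compound in the circulation, a higher number more compound in the circulation at the dose given), compound 3 gives the lowest of the three numbers. Compound 2 lies nearest, and the step of a 1.8-fold lower number from compound 2 to compound 3 (0.26 log units; within the scatter) is within the scatter; compound 1 lies furthest, and the step of an 8.7-fold lower number from compound 1 to compound 3 (0.94 log units; beyond the scatter) is beyond it. Compound 4 `COc1ccc(C(=O)NC2CCCC2)cc1-c1[nH]nc2nc(Nc3ccc(F)cc3F)ccc12` differs from compound 3 by cyclopentyl in place of oxan-4-yl on an amide-type nitrogen. Going by the values given here, no measured step varies the group on this amide-type nitrogen: the steps of an 8.7-fold lower number from compound 1 to compound 3 (0.94 log units; beyond the scatter) and a 1.8-fold lower number from compound 2 to compound 3 (0.26 log units; within the scatter) introduce the (oxan-4-yl)carbamoyl group as a whole, and the step of a 4.7-fold lower number from compound 1 to compound 2 (0.67 log units; beyond the scatter) concerns a different group on the aromatic carbon. For compound 4 the expected step of a 1.2-fold higher number from compound 3 to compound 4 (0.07 log units; within the scatter) is therefore none beyond the scatter. Compound 4 is estimated at 7 nM, in a range from 2.5 nM to 20 nM.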

Compound 4, maximal plasma concentration: 6 nM
For compound 4 the middle estimate is 1.2-fold (0.07 log units) above the measured one, and the stated range covers the measured number.
By their numbers in this assay, from the lowest: compounds 3, 4 and 2 (each within the scatter of the next); then compound 1.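

In this assay, going by these compounds alone, this is the first step that varies the group on the amide-type nitrogen, and cyclopentyl in place of oxan-4-yl gives no change at the digits printed from compound 3 to compound 4 (within the scatter), so here the ring oxygen can go without a readable shift. The cyclopentylcarbamoyl group stands as the (oxan-4-yl)carbamoyl group did against the other two groups on the aromatic carbon, with a 1.8-fold lower number from compound 2 to compound 4 (0.26 log units; within the scatter) and an 8.7-fold lower number from compound 1 to compound 4 (0.94 log units; beyond the scatter). Nothing at hand explains these results. Still open, on these data alone, is whether an amine, a carboxylic acid or a longer chain on this nitrogen would move the number beyond the scatter.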